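The compounds below may be only part of what the source reports. "The series", "measured", "known", "first", "only" and "open" are said of these compounds alone.

Two compounds have so far been measured in an assay on HEK293 cells for positive allosteric modulation of metabotropic glutamate receptor 2 (Rattus norvegicus), read by thallium flux, with a stated time of 2.5 min; on this read-out lower numbers stand for an effect already at smaller amounts and higher numbers for an effect only at larger amounts of compound:

compound 1 `CCCC(=O)c1ccc(OCCCCOc2ccc(F)c(C(=O)O)c2)c(C)c1O`: 74 nM
compound 2 `CCCC(=O)c1ccc(OCCCCOc2cccc(C(=O)O)c2C)c(C)c1O`: 52 nM

Compound 2 shows the lower of the two numbers in this assay, but its gap to compound 1 is within the usual scatter of repeated measurements, so the two compounds cannot be told apart on these data. Both share the same core, a ketone-bearing ring joined through a four-carbon linker to a second ring that carries a carboxylic acid; they differ only in how that acid-bearing ring is substituted.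

Compound 3 `Cc1c(OCCCCOc2ccc(C(=O)CC(C)(C)C)c(O)c2C)cccc1C(=O)O` has not yet been measured in this assay. It keeps the acid-bearing ring of compound 2 and changes only the alkyl chain attached to the ketone: tert-butyl in place of ethyl on a saturated chain carbon bound to a carbonyl carbon. Among the compounds with values here, no pair of measured compounds shows what such a change does here, and the structural difference does not touch the ring substitution that separates compound 1 from compound 2. The change from compound 2 to compound 3 is therefore expected to give a step of a 1.2-fold higher number from compound 2 to compound 3 (0.06 log units; within the scatter), that is, no shift beyond the scatter in either direction. On that basis compound 3 is estimated at 60 nM in this assay, with a plausible range from 20 nM to 200 nM.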

Compound 3, half-maximal effective concentration: 136 nM
Beside the measured number, compound 3's estimate is 2.3-fold (0.36 log units) below it, and the stated range covers the measured number.
By their numbers in this assay, from the lowest: compounds 2, 1 and 3 (each within the scatter of the next, the first and the last beyond it).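

This is the first step among these compounds that lies beyond the scatter: in this assay, tert-butyl in place of ethyl on a saturated chain carbon bound to a carbonyl carbon gives a 2.6-fold higher number from compound 2 to compound 3 (0.42 log units; beyond the scatter). The earlier compounds shown here differed only in how the acid-bearing ring is substituted, so they said nothing about this chain; now it is clear that, with that ring held constant, a change in the alkyl chain on the ketone alone can modestly shift the number toward an effect only at larger amounts of compound. No measurement shown here explains why this replacement moves the number in this direction.

A single step cannot show whether the shift follows from the added carbons or from the branching of tert-butyl, and an unbranched butyl or an isopropyl group at the same place would be needed to tell these apart. As far as these compounds go, it also remains open whether a chain carrying an amine or a hydroxyl group would be tolerated here, and whether the same replacement would give a similar step on the acid-bearing ring of compound 1.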